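The source may hold more compounds than are shown below. What is called first, only, known or untested is meant among the compounds shown, and "the series" means these compounds.

Working notes on the series. Among the measured compounds shown here, compound 2 `CC1(C)Cc2c(sc(NC(=O)C(C)(C)CO)c2C(N)=O)C(C)(C)O1` stands at the higher end of the two numbers so far: in an assay on cells for positive allosteric modulation of Cystic fibrosis transmembrane conductance regulator variant F508del (Homo sapiens), with stated times of 10 min and 7 s, in the presence of a further agent that is not named here (on this read-out higher numbers stand for an effect only at larger amounts of compound and lower numbers for an effect already at smaller amounts), compound 2 gives 75 nM, and its only neighbour, compound 1 `CC1(C)Cc2c(sc(NC(=O)C3(O)CC3)c2C(N)=O)C(C)(C)O1`, gives 23 nM in this assay. For the measured compounds named here, the single measured step runs a 3.3-fold higher number from compound 1 to compound 2 (0.51 log units; beyond the scatter); both compounds carry a hydroxyl-bearing group on the carbonyl carbon, and the two differ only in that group.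

The next step leads to compound 3 `CC1(C)Cc2c(sc(NC(=O)[C@@H](O)C(C)(C)C)c2C(N)=O)C(C)(C)O1`, which differs from compound 2 as 1-hydroxy-2,2-dimethylpropyl in place of 1-(hydroxymethyl)-1-methylethyl on a carbonyl carbon. The entering group shares with the 1-hydroxycyclopropyl of compound 1 the 1-hydroxy pattern of its name, while the chain grows by one carbon. Going by the values given here, only the step from compound 1 to compound 2 bears on this change, and it was modest, so a step of comparable size in this assay, more likely towards lower numbers, is expected for compound 3 because compound 1 with its 1-hydroxycyclopropyl gave 23 nM. For compound 3 the expected value is 40 nM, with a range of 12 nM to 130 nM. The step this expectation implies, a 1.9-fold lower number from compound 2 to compound 3 (0.27 log units; within the scatter), rests on one measured pair only.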

Compound 3, half-maximal effective concentration: 2.7 nM
Estimate against measurement, compound 3: 15-fold (1.17 log units) above; measured number below the stated range.
By their numbers in this assay, from the lowest: compound 3; then compound 1; then compound 2.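

In this assay the change on the carbonyl carbon runs a 28-fold lower number from compound 2 to compound 3 (1.44 log units; beyond the scatter), a step much larger than the earlier 3.3-fold higher number from compound 1 to compound 2 (0.51 log units; beyond the scatter), although the hydrogen-bond donor and acceptor counts stay the same and neither group has a ring, so this position is more sensitive to the arrangement of the group than the first pair showed. The 1-hydroxy pattern alone does not set the number: the change from 1-hydroxycyclopropyl to 1-hydroxy-2,2-dimethylpropyl still gives an 8.5-fold lower number from compound 1 to compound 3 (0.93 log units; beyond the scatter), and among these three compounds the two with a 1-hydroxy group both lie below compound 2, with none going against this. No measurement at hand explains either step.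

Compound 3 has one defined stereocentre. The compounds shown leave open what the opposite configuration of the 1-hydroxy-2,2-dimethylpropyl group gives. They also leave open whether an amine or a methoxy group could replace the hydroxyl on this chain, and whether a longer chain in place of the 2,2-dimethylpropyl would hold the number.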